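Ethylamino in Place of Propyl on the Carbonyl Carbon

The source may hold more compounds than are shown below. What is called first, only, known or untested is meant among the compounds shown, and "the series" means these compounds.

Going by the values given here, compound 1 `CCCC(=O)Nc1ccc(S(=O)(=O)Oc2ccccc2C(C)C)cc1` is one of three compounds measured in a functional assay on M21 cells (Homo sapiens) for antiproliferative activity, read by sulforhodamine B assay, with a stated time of 48 h; a lower number here means a stronger inhibitor, a higher number a weaker inhibitor. In this assay compound 1 gives 6100 nM, the lowest of the three numbers, though neither companion lies beyond the scatter of it. Compound 2 `CCCC(=O)Nc1ccc(S(=O)(=O)Oc2ccccc2I)cc1` gives 9000 nM, and the step of a 1.5-fold higher number from compound 1 to compound 2 (0.17 log units; within the scatter) accompanies iodo in place of isopropyl on an aromatic carbon. Compound 3 `O=C(CCCCl)Nc1ccc(S(=O)(=O)Oc2ccccc2I)cc1` gives 7200 nM, and the step of a 1.3-fold lower number from compound 2 to compound 3 (0.10 log units; within the scatter) accompanies chloro in place of hydrogen on a saturated chain carbon, three bonds along the chain from a carbonyl carbon. Neither step moves the number beyond the scatter.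

Compound 4 `CCNC(=O)Nc1ccc(S(=O)(=O)Oc2ccccc2C(C)C)cc1` differs from compound 1 in one place: ethylamino in place of propyl on a carbonyl carbon. Neither measured step alters the carbonyl carbon in this way, so the two steps bear on the question only indirectly, as a sign that changes at both ends of the shared core have so far left the number in a narrow band. The account therefore expects no step beyond the scatter from compound 1 to compound 4, while allowing a wide range for a change of a kind not yet seen here. The expected step is a 1.1-fold higher number from compound 1 to compound 4 (0.06 log units; within the scatter). Compound 4 is expected to give 7000 nM, between 2500 nM and 20000 nM.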

Compound 4, half-maximal inhibitory concentration: 4700 nM
Beside the measured number, compound 4's estimate is 1.5-fold (0.17 log units) above it; low and high end bracket the measured number.
By their numbers in this assay, from the lowest: compounds 4, 1, 3 and 2 (each within the scatter of the next).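

In this assay, exchanging propyl for ethylamino on the carbonyl carbon gives a 1.3-fold lower number from compound 1 to compound 4 (0.11 log units; within the scatter), so the step stays within the scatter. Where compound 3 only adds chloro to a chain that is otherwise kept, this step replaces the propyl itself, turning (propylcarbonyl)amino into (ethylcarbamoyl)amino, and shows that a nitrogen and a hydrogen-bond donor can enter at this place, with the heavy-atom count unchanged, without a change in the number that can be told from scatter. The compounds shown offer no measurement that accounts for this result, and no reason can be given for it.

The compounds shown leave open whether a longer chain such as butylamino, a branched isopropylamino or a dimethylamino group on the carbonyl carbon would also stay within the scatter of compound 1, or whether one of them would produce a step beyond it. They also leave open whether ethylamino on the carbonyl carbon would give a similar step with iodo in place of isopropyl on the aromatic carbon, as in compound 2.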